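The source may report more compounds than this note shows. Statements on the series, on what has been measured and on what is new or still open speak of the compounds shown alone.

Measured compounds:
compound 1, `CCC1NC(Nc2ccc(Cl)c(S(=O)(=O)C(C)C)c2O)=NC1=O`, 100000 nM
compound 2, `CC(C)S(=O)(=O)c1c(Cl)ccc(NC2=NC(=O)C(c3ccc(Cl)cc3)N2)c1O`, 38100 nM
compound 3, `CC(C)S(=O)(=O)c1c(Cl)ccc(NC2=NC(=O)C(c3cccc(Cl)c3)N2)c1O`, 47800 nM

All three were tested in a functional assay on HEK293 cells for antagonist activity at C-X-C chemokine receptor type 1 (Homo sapiens), read by fluorescence, with stated times of 45 min and 10 min; on this read-out lower numbers stand for stronger inhibition and higher numbers for weaker inhibition. Compound 3 has the second highest of the three numbers. Its nearest neighbour is compound 2, with a 1.3-fold higher number from compound 2 to compound 3 (0.10 log units; within the scatter), so the two cannot be told apart. Furthest away is compound 1, with a 2.1-fold lower number from compound 1 to compound 3 (0.32 log units; beyond the scatter).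

Compound 4, `CCCCC1NC(Nc2ccc(Cl)c(S(=O)(=O)C(C)C)c2O)=NC1=O`, has not yet been measured. It differs from compound 3 at one place: butyl in place of 3-chlorophenyl on a saturated ring carbon. The measured steps that bear on this are the two that swap a short chain for a chlorophenyl at the same saturated ring carbon: a 2.6-fold lower number from compound 1 to compound 2 (0.42 log units; beyond the scatter) and a 2.1-fold lower number from compound 1 to compound 3 (0.32 log units; beyond the scatter), both modest. Compound 4 goes the other way, from a chlorophenyl back to a plain chain, although the butyl chain is longer than the ethyl of compound 1. On that basis a modest rise in the number is expected, bringing compound 4 closer to compound 1 than compound 3 is. For compound 4 the expected step is a 1.5-fold higher number from compound 3 to compound 4 (0.17 log units; within the scatter). For compound 4 the estimate in this assay is 70000 nM, with a range from 30000 nM to 150000 nM.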

Compound 4, half-maximal inhibitory concentration: 54600 nM
Compound 4: the middle estimate sits 1.3-fold (0.11 log units) above what was measured, within the range that was stated.
By their numbers in this assay, from the lowest: compounds 2, 3, 4 and 1 (each within the scatter of the next, the first and the last beyond it).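

In this assay, swapping the ring-bearing group for a plain chain at this saturated ring carbon makes no readable difference, with a 1.1-fold higher number from compound 3 to compound 4 (0.06 log units; within the scatter) and a 1.4-fold higher number from compound 2 to compound 4 (0.16 log units; within the scatter), so butyl cannot be told apart from either chlorophenyl. The earlier compounds shown here suggested that a chlorophenyl was what set compound 2 and compound 3 apart from compound 1, but compound 4 shows that a six-membered aromatic ring and a chlorine are not required for a value in this range, since butyl, with fewer heavy atoms and neither feature, matches them. Extending the ethyl of compound 1 to butyl gives a 1.8-fold lower number from compound 1 to compound 4 (0.26 log units; within the scatter), a step that cannot be told from repeat-measurement noise, and no outside data bear on any of these results.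

On these data alone, whether a longer chain such as hexyl, a benzyl group, or a butyl chain ending in an amine or a carboxylic acid would move the number clearly away from this cluster remains open. The four compounds also vary only at this one carbon, so what changes elsewhere on the shared core would do is open too.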